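Antiproliferative series: from compound 1 to compound 4

The source may hold more compounds than are shown below. What is called first, only, known or untested is meant among the compounds shown, and "the series" means these compounds.

Measured in a functional assay on A549 cells (Homo sapiens) for antiproliferative activity, read by MTT assay, with a stated time of 72 h; on this read-out higher numbers stand for weaker inhibition and lower numbers for stronger inhibition:
- compound 1 `COc1ncc(-c2ccc3c(c2)N(c2ccc(C)cc2)C(=O)CO3)cc1NS(=O)(=O)c1ccc(F)cc1`: 5870 nM
- compound 2 `O=C1COc2ccc(-c3cccc(NS(=O)(=O)c4ccc(F)cc4)c3)cc2N1`: 32100 nM
- compound 3 `COc1ccc(N2C(=O)COc3ccc(-c4ccc(O)cc4)cc32)cc1`: > 40000 nM, a limit of the assay

Of the two true numbers, compound 1 at 5870 nM is the lower, and compound 2 at 32100 nM lies higher, beyond the usual scatter. For compound 3 the entry > 40000 nM is a limit and not a number.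

Compound 4 `COc1cccc(N2C(=O)COc3ccc(-c4cnc(OC)c(NS(=O)(=O)c5ccc(F)cc5)c4)cc32)c1` is not yet measured. It carries 3-methoxyphenyl in place of 4-methylphenyl on an amide-type nitrogen in a ring. Going by the values given here, no pair of measured compounds isolates this change. In this assay the step is therefore expected to stay within the scatter, with neither direction favoured, and the expectation starts from compound 1 at 5870 nM. The expected step is a 1.1-fold higher number from compound 1 to compound 4 (0.04 log units; within the scatter). Compound 4 is estimated at 6500 nM, with an expected range of 2200 nM to 20000 nM.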

Compound 4, half-maximal inhibitory concentration: 11200 nM
Beside the measured number, compound 4's estimate is 1.7-fold (0.24 log units) below it; measured number inside the range.
By their numbers in this assay, from the lowest: compounds 1 and 4 (each within the scatter of the next); then compound 2. At a limit, above all of these: compound 3.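

Working notes: in this assay, this is the first reading of a single exchange on the amide-type nitrogen in a ring, and the step is a 1.9-fold higher number from compound 1 to compound 4 (0.28 log units; within the scatter). At this position, then, 3-methoxyphenyl and 4-methylphenyl do not separate: the one additional heavy atom, an oxygen, and the one hydrogen-bond acceptor that enter with 3-methoxyphenyl leave the read-out within the scatter of compound 1. The data shown offer no measurement that would explain this step.

Both groups read so far are six-membered aromatic rings of carbon only, so the reach of this position remains undefined. Still open, going by these compounds, is how the series would read with an amine or a carboxylic acid on that ring, or with a longer alkyl chain on the same nitrogen in place of the ring.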